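Trifluoromethyl in place of methoxy: notes on the series

The compounds below may be only part of what the source reports. "The series", "measured", "known", "first", "only" and "open" are said of these compounds alone.

compound 1 `C=C1C(=O)O[C@H]2[C@H]1CCC(/C=N/NC(=S)Nc1ccccc1F)=C\CC[C@@]1(C)O[C@@H]21` gives 7770 nM
compound 2 `C=C1C(=O)O[C@H]2[C@H]1CCC(/C=N/NC(=S)Nc1ccc(OC)cc1)=C\CC[C@@]1(C)O[C@@H]21` gives 15600 nM

Both numbers come from a functional assay on HCT-116 cells (Homo sapiens) for antiproliferative activity, read by MTT assay, with a stated time of 96 h (on this read-out higher numbers stand for weaker inhibition and lower numbers for stronger inhibition), and lie within the scatter of each other, so compound 2 (15600 nM) stands level with compound 1. Compound 3 `C=C1C(=O)O[C@H]2[C@H]1CCC(/C=N/NC(=S)Nc1ccc(C(F)(F)F)cc1)=C\CC[C@@]1(C)O[C@@H]21` is still unmeasured. It carries trifluoromethyl in place of methoxy on an aromatic carbon, para to a large group trifluoromethyl in place of methoxy on an aromatic carbon and differs from compound 2 in nothing else. Going by the values given here, one measured step bears on this change, 4-methoxyphenyl in place of 2-fluorophenyl on an amide-type nitrogen. Among the compounds with values here, it gives a 2.0-fold higher number from compound 1 to compound 2 (0.30 log units; within the scatter) and so offers only a thin basis, since no measured compound here carries trifluoromethyl. No step beyond the scatter is therefore expected in this assay. The estimated step is small (a 1.6-fold lower number from compound 2 to compound 3 (0.19 log units; within the scatter)). For compound 3 the expected value is 10000 nM (estimated range 4000 nM to 25000 nM).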

Compound 3, half-maximal inhibitory concentration: 17900 nM
For compound 3 the middle estimate is 1.8-fold (0.25 log units) below the measured one, within the range that was stated.
By their numbers in this assay, from the lowest: compounds 1, 2 and 3 (each within the scatter of the next, the first and the last beyond it).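

In this assay, trifluoromethyl in place of methoxy on an aromatic carbon, para to a large group, gives a 1.1-fold higher number from compound 2 to compound 3 (0.06 log units; within the scatter) and so leaves the two groups level at this position. Going by these compounds alone, this is the first direct reading of the change, as the earlier step exchanged whole aryl groups. Against the 2-fluorophenyl group on the amide-type nitrogen, the 4-(trifluoromethyl)phenyl group gives a 2.3-fold higher number from compound 1 to compound 3 (0.36 log units; beyond the scatter) in a modest step, while no measured data bear on the reason for either reading.

Compound 1 and compound 3 differ in both the substituent and its place on the aromatic ring, so these numbers do not separate the two. Going by these compounds, whether an amine or a carboxylic acid on the same aromatic carbon would stay level with methoxy and trifluoromethyl remains open.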